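Tert-butyl in place of methyl on the aryl urea

The source may hold more compounds than are shown below. What is called first, only, known or untested is meant among the compounds shown, and "the series" means these compounds.

Measured so far:
compound 1 `Cc1ccccc1NC(=O)N[C@H](C)c1ccccc1` gives 99%
compound 2 `Cc1ccccc1NC(=O)N[C@@H](C)c1ccccc1` gives 99%
compound 3 `CCc1cccc(NC(=O)N[C@@H](C)c2ccccc2)c1` gives 86%

In an ADME assay on the whole organism with Oryza sativa as the target, tested at 10 uM (on this read-out higher numbers stand for a weaker effect at the one concentration tested and lower numbers for a stronger effect), compound 2 stands level with compound 1, the two together the highest of the three numbers, while compound 3 lies lower by a margin beyond the scatter. The step of no change at the digits printed from compound 1 to compound 2 (within the scatter) is explained by the fact that compounds 1 and 2 differ only in the configuration as drawn. Compound 4 `C[C@H](NC(=O)Nc1ccccc1C(C)(C)C)c1ccccc1` differs from compound 2 by tert-butyl in place of methyl on an aromatic carbon. Within the data shown here, no measured step changes a group on this ring in one place, so no measured step bears on it directly. He therefore expects at most a small step of a number 7 percentage points lower from compound 2 to compound 4 (within the scatter), if any beyond the scatter, with compound 4 estimated at 92% within 76% to 100%.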

Compound 4, a percentage reported as activity, at one concentration (the size of the read-out at that concentration, not a potency): 100%
Beside the measured number, compound 4's estimate is 8 percentage points below it; the measured number falls inside the stated range.
By their numbers in this assay, from the lowest: compound 3; then compounds 1, 2 and 4 (each within the scatter of the next).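

In this assay, among these compounds, tert-butyl in place of methyl on this aromatic carbon gives a number 1 percentage points higher from compound 2 to compound 4 (within the scatter) and is the first measured one-place change on this ring. At this position, going from 1 heavy atom to 4 heavy atoms thus leaves the read-out within the scatter. Nothing in the evidence at hand bears on this result.

From the compounds shown here alone, whether an amine or a carboxylic acid at this place would move the read-out beyond the scatter remains open. So does whether the opposite configuration would matter with tert-butyl in place.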